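The source may report more compounds than this note shows. Statements on the series, on what has been measured and on what is new or still open speak of the compounds shown alone.

Compound 1 `Cc1ccccc1OCC(O)CNCC(=O)Nc1ccc(C2=NNC(=O)CC2)cc1`: 2 umol/kg
Compound 2 `Cc1ccccc1OCC(O)CNCC(=O)Nc1ccc(C2=NNC(=O)CC2C)cc1`: 2.7 umol/kg

These two values come from a functional assay on the whole organism with Rattus norvegicus as the target; a lower number here means that less compound is needed, a higher number that more compound is needed for the effect. Among the measured compounds shown here, compound 1, at 2 umol/kg, has only one measured neighbour, and the two lie within the scatter of each other, so neither can be ranked above the other.

The next compound to be tested is compound 3 `COc1ccccc1OCC(O)CNCC(=O)Nc1ccc(C2=NNC(=O)CC2)cc1`. It keeps the core of compound 1 but carries methoxy in place of methyl on an aromatic carbon, so that 2-methylphenoxy becomes 2-methoxyphenoxy: methoxy in place of methyl on an aromatic carbon.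

For the measured compounds named here, the only measured step is a 1.4-fold higher number from compound 1 to compound 2 (0.13 log units; within the scatter). It is a methyl in place of hydrogen on a saturated ring carbon, which lies elsewhere in the molecule, so it offers only indirect guidance. It does show that one small change left this assay within the scatter. Going by the values given here, no measured step tests the aromatic position itself, so the range must stay wide.

No step beyond the scatter is expected, and the estimated step is a 1.1-fold higher number from compound 1 to compound 3 (0.04 log units; within the scatter). For compound 3 the expected value is 2.2 umol/kg, with an estimated range from 0.7 umol/kg to 7 umol/kg.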

Compound 3, dose for half-maximal effect: 4.6 umol/kg
Compound 3: middle estimate off by 2.1-fold (0.32 log units), on the low side, and the stated range covers the measured number.
By their numbers in this assay, from the lowest: compounds 1, 2 and 3 (each within the scatter of the next, the first and the last beyond it).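

In this assay, putting methoxy in place of methyl on the aromatic carbon gives a 2.3-fold higher number from compound 1 to compound 3 (0.36 log units; beyond the scatter) and so takes more compound for the same effect, though the step is modest. This shows that the group at this position, on a six-membered aromatic ring and ortho to a large group, can move the number beyond the usual scatter, whereas the earlier change on a saturated ring carbon, elsewhere in the molecule, gave only a 1.4-fold higher number from compound 1 to compound 2 (0.13 log units; within the scatter) and stayed within it. The swap adds an oxygen and a hydrogen-bond acceptor to the count, but no measurement here explains why the number rises.

On these data alone, only methyl and methoxy are compared at this position, so it remains open whether hydrogen, chlorine, ethoxy or hydroxyl there would fall closer to compound 1 or to compound 3. As far as these compounds go, it is also open whether methoxy would give a step of similar size on the core of compound 2, which carries the extra methyl on the saturated ring carbon.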